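This account rests on a few compounds, and the source may have more. Where it says the series, first, only, none or still open, it means among the compounds named here.

In a functional assay on MCF7 cells (Homo sapiens) for inhibition, read by MTT assay, with a stated time of 72 h (a higher number here means a weaker inhibitor, a lower number a stronger inhibitor), compound 1 `CC(C)=CCC[C@H](C)c1ccc(C)c(CNCC2CCNCC2)c1O` gives > 20000 nM, which is a limit and not a number. Compound 4 `CC(C)=CCC[C@H](C)c1ccc(C)c(CNCCCCC(=O)O)c1O` differs from it by 3-carboxypropyl in place of piperidin-4-yl on a saturated chain carbon bound to an amine nitrogen. The nearest measured evidence comes from compound 2 `CC(C)=CCC[C@H](C)c1ccc(C)c2c1OCN(CCCCCO)C2`, which gives 6900 nM. Compound 3 `CC(C)=CCC[C@H](C)c1ccc(C)c2c1OCN(CCCCC(=O)O)C2` gives > 20000 nM, also a limit. The carboxy for hydroxymethyl exchange is a step of an at least 2.8-fold higher number from compound 2 to compound 3 (0.46 log units; beyond the scatter), beyond the scatter and towards weaker inhibition. With that step pointing the wrong way for any gain, no step beyond the scatter is expected, and the estimated change is a step that the limit leaves unreadable from compound 1 to compound 4. For compound 4 the expected value is 25000 nM, with an estimated range of 12000 nM to 50000 nM.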

Compound 4, half-maximal inhibitory concentration: > 20000 nM
Compound 4: only a limit was reported; the forecaster's own chance of this, stated with the estimate: 75%; the middle value lies beyond the limit too.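

In this assay, compound 1 and compound 4 are both reported only as limits, so no step between them can be read: the limit of > 20000 nM in this assay, at which 3 of the 4 values shown sit.

On these data alone, whether 3-carboxypropyl or piperidin-4-yl on a saturated chain carbon bound to an amine nitrogen gives the stronger inhibitor stays open.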